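A few compounds are considered here, and "the series" means these few. Any claim that something is new, unique, unknown or untested is made for them only; others in the source may bear on it.

Working notes on the series. In an ADME assay on HEK293 cells (Homo sapiens) for cytotoxicity, read by MTT assay, with a stated time of 48 h (a higher number here means a weaker inhibitor, a lower number a stronger inhibitor), compound 2 `COc1cc(NC(=O)c2ccc(Cl)cc2)ccc1NS(C)(=O)=O` gives only a limit, > 250000 nM. That value is the limit of > 250000 nM in this assay, at which 1 of the 2 values shown sits. Compound 1 `Cc1cc(NC(=O)c2ccc(Cl)c([N+](=O)[O-])c2)ccc1NS(C)(=O)=O` sits in the same set and in this assay gives 73100 nM. Compound 3 `COc1cc(NC(=O)c2ccc(Cl)c([N+](=O)[O-])c2)ccc1NS(C)(=O)=O` is not yet measured; it differs from compound 2 by nitro in place of hydrogen on an aromatic carbon. Among the compounds with values here, no step between measured compounds is available, so the expected size is uncertain; a move toward a measurable number is expected because compound 1 shows 73100 nM. For compound 3 the estimate is 90000 nM, between 30000 nM and 250000 nM, an expected step of an at least 2.7-fold lower number from compound 2 to compound 3 (0.44 log units; beyond the scatter).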

Compound 3, half-maximal inhibitory concentration: 164000 nM
The estimate for compound 3 lay 1.8-fold (0.26 log units) below the measured number, and the stated range covers the measured number.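

In this assay, nitro in place of hydrogen on an aromatic carbon, ortho to a chloro group, gives an at least 1.5-fold lower number from compound 2 to compound 3 (0.18 log units; that floor lies within the scatter), so the true size of this change stays unfixed. The step can be read only as a floor because compound 2 carries a limit: the limit of > 250000 nM in this assay, at which 1 of the 3 values shown sits. Within the data shown here, with nitro kept, methoxy in place of methyl on an aromatic carbon gives a 2.2-fold higher number from compound 1 to compound 3 (0.35 log units; beyond the scatter), the first readable step for that swap.

Going by these compounds, whether an amine or a carboxylic acid at the nitro position would read differently stays open. So does the size of the methoxy-for-methyl step without nitro.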